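The source may report more compounds than this note shows. Statements on the series, on what has been measured and on what is new or still open speak of the compounds shown alone.

Measured so far:
- compound 1, `O=S(=O)(c1cccc(Cl)c1)N1CCOc2c(N3CCNCC3)cccc21`, 2 nM
- compound 2, `O=S(=O)(c1ccccc1F)N1CCOc2c(N3CCNCC3)cc(F)cc21`, 0.631 nM

Both numbers come from an assay on HEK293 cells for displacement of a labelled ligand from 5-hydroxytryptamine receptor 6 (Homo sapiens); a lower number here means a stronger inhibitor, a higher number a weaker inhibitor. Of the two, compound 2 has the lower number; compound 1 shows a higher number in this assay, and the gap between the two lies beyond the usual scatter of repeated measurements. The two compounds differ from each other in more than one place, so no single change can be tied to that gap.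

Compound 3, `COc1cc(N2CCNCC2)c2c(c1)N(S(=O)(=O)c1ccccc1F)CCO2`, has not yet been measured. It is built from compound 2 by one change: methoxy in place of fluoro on an aromatic carbon. The methoxy group therefore takes the place of the fluorine on the aromatic carbon that is meta to a piperazin-1-yl group, while the rest of the molecule, including the sulfonyl-bearing ring and the piperazine, stays as it is in compound 2.

Going by the values given here, no measured pair shows what such an exchange does in this assay, so the expectation rests on compound 2 alone. The step from compound 2 to compound 3 is expected to be small, a 1.6-fold higher number from compound 2 to compound 3 (0.20 log units; within the scatter), likely within the scatter. For compound 3 the estimated value in this assay is 1 nM, with a range from 0.3 nM to 4 nM.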

Compound 3, inhibition constant: 0.159 nM
Compound 3: the middle estimate sits 6.3-fold (0.80 log units) above what was measured, outside the stated range (below it).
By their numbers in this assay, from the lowest: compound 3; then compound 2; then compound 1.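

In this assay, going by these compounds alone, putting methoxy in place of fluoro gives a 4.0-fold lower number from compound 2 to compound 3 (0.60 log units; beyond the scatter), the first change in this set that can be tied to a single place on the shared core. This shows that the group on this aromatic carbon, meta to a piperazin-1-yl group and para to a fused ring, affects the number beyond the usual scatter. It also shows that this carbon can carry methoxy, with two heavy atoms and one hydrogen-bond acceptor, in place of fluoro, with one heavy atom and no acceptor, and the number still falls. Nothing measured here explains why the number falls.

A single step cannot show whether the gain is particular to methoxy or would also appear with another group on this carbon, such as ethoxy, hydroxyl or an amine. It also leaves open whether methoxy would bring a similar step on the core of compound 1, which carries a chloro group on its sulfonyl-bearing ring.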